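The source may report more compounds than this note shows. Statements on the series, on what has been measured and on what is new or still open speak of the compounds shown alone.

Three compounds have been measured in a functional assay on PC-12 cells (Rattus norvegicus) for cytotoxicity, read by MTT assay, with stated times of 2 h and 24 h, tested at 5 uM; on this read-out higher numbers stand for a stronger effect at the one concentration tested and lower numbers for a weaker effect:

Compound 1 `CCc1ccc(-n2nc(-c3ccc(C(F)(F)F)cc3O)nc2-c2ccccc2O)cc1` gives 95.4%.
Compound 2 `Oc1cc(C(F)(F)F)ccc1-c1nc(-c2ccccc2O)n(-c2ccc(Br)cc2)n1` gives 89.8%.
Compound 3 `N#Cc1ccc(-n2nc(-c3ccc(C(F)(F)F)cc3O)nc2-c2ccccc2O)cc1` gives 86.8%.

Compound 2 holds the second highest of the three numbers in this assay. Its nearest neighbour is compound 3, separated by a number 3 percentage points lower from compound 2 to compound 3 (within the scatter); its furthest gap is a number 5.6 percentage points lower from compound 1 to compound 2 (within the scatter). All three values thus sit within the scatter of one another, and no order among them can be read from these data.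

Compound 4 `Oc1cc(C(F)(F)F)ccc1-c1nc(-c2ccccc2O)n(-c2ccc(F)cc2F)n1` has not yet been measured. It differs from compound 2 in one place: 2,4-difluorophenyl in place of 4-bromophenyl on an aromatic nitrogen. The measured steps that bear on this change are those in which the group on an aromatic carbon of the same phenyl was swapped: a number 5.6 percentage points lower from compound 1 to compound 2 (within the scatter), a number 8.6 percentage points lower from compound 1 to compound 3 (within the scatter) and a number 3 percentage points lower from compound 2 to compound 3 (within the scatter). Each of them stayed within the scatter. Whether swapping two fluorines for one bromine on that phenyl behaves in the same way is not shown by any measured pair, but nothing seen so far points to a shift beyond the scatter in this assay.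

Compound 4 is therefore expected to give about 88%, within 77% to 97%. The step from compound 2 is expected to be a number 1.8 percentage points lower from compound 2 to compound 4 (within the scatter).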

Compound 4, a percentage reported as activity, at one concentration (the size of the read-out at that concentration, not a potency): 83.5%
For compound 4 the middle estimate is 4.5 percentage points above the measured one; the measured number falls inside the stated range.
By their numbers in this assay, from the lowest: compounds 4, 3, 2 and 1 (each within the scatter of the next, the first and the last beyond it).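

In this assay, the group on the aromatic nitrogen now gives its first step beyond the scatter (a number 11.9 percentage points lower from compound 1 to compound 4 (beyond the scatter)), so a change at this position can register in the read-out, although only modestly and only for 2,4-difluorophenyl in place of 4-ethylphenyl. The same group cannot be told apart from the other two groups tested at this position: the comparisons with 4-bromophenyl (a number 6.3 percentage points lower from compound 2 to compound 4 (within the scatter)) and 4-cyanophenyl (a number 3.3 percentage points lower from compound 3 to compound 4 (within the scatter)) both stay within the scatter, so the four compounds do not separate into clear classes. Among these compounds, no measurement here accounts for the one larger step.

The compounds shown leave open whether an amine or a carboxylic acid on this phenyl, or a propyl or longer chain in place of its ethyl, would carry the read-out further from that of compound 1. Among the compounds shown here, they also leave open whether a single fluorine would give the same result as two, and whether the one step beyond the scatter would hold at concentrations other than the single one tested.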